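The source may hold more compounds than are shown below. What is called first, only, known or untested is meant among the compounds shown, and "the series" means these compounds.

Measured so far:
compound 1 `CCCCN1/C(=C/C=C/c2sc3ccccc3[n+]2CCCC)Sc2ccccc21` — in an assay for displacement of a labelled ligand from protein arginine N-methyltransferase 1 (Homo sapiens), read by scintillation proximity assay, with stated times of 5 min and 8 min, tested at 10 uM (a lower number here means a weaker effect, a higher number a stronger effect of the compound at the concentration tested), compound 1 gives 79%
compound 2 `CN1/C(=C/C=C/C2=[N+](CCC[N+](C)(C)C)c3ccc(S(=O)(=O)[O-])cc3C2(C)C)C(C)(C)c2ccccc21` — in this assay compound 2 is reported as "not active" (no number reported), with no number given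
compound 3 `C(/C=C/c1sc2ccccc2[n+]1CCCc1ccccc1)=C1/Sc2ccccc2N1CCCc1ccccc1` — in this assay compound 3 gives 76%

Compound 1 and compound 3 sit close to each other in this assay, and the two values lie within the usual scatter of one another. Compound 2 stands apart: the read-out for compound 2 carries no number at all, only the statement that no effect was seen, so nothing can be said about its size beyond that it lies at the weak end.

Compound 4 `CN1/C(=C/C=C/C2=[N+](CCC[N+](C)(C)C)c3ccccc3C2(C)C)C(C)(C)c2ccccc21` is compound 2 with a single change: a hydrogen atom in place of a group of 4 heavy atoms (3 oxygen, 1 sulfur; no ring), on an aromatic carbon. For the measured compounds named here, no measured pair shows this change, so its size has to be guessed. In this assay a move upward from compound 2 to compound 4 is expected, likely beyond the scatter, but the absent number for compound 2 leaves the starting point undefined and the expectation loose.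

For compound 4 the estimated value in this assay is 30%, with a range from 0% to 65%.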

Compound 4, a percentage reported as inhibition, at one concentration (the size of the read-out at that concentration, not a potency): 2%
For compound 4 the middle estimate is 28 percentage points above the measured one; the range from low to high includes it.
By their numbers in this assay, from the lowest: compound 4; then compounds 3 and 1 (each within the scatter of the next).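

No step can be read from compound 2 to compound 4 in this assay, since compound 4 gives 2% and compound 2 carries no number. The compounds shown leave open whether the hydrogen in place of the group of 4 heavy atoms changes the read-out at all. No available measurement bears on this result.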